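The source may hold more compounds than are shown below. What is called first, only, known or untested is meant among the compounds shown, and "the series" means these compounds.

Measured compounds:
- compound 1, `COc1cc(N2C(=S)SCC2(O)c2ccc(Br)cc2)cc(OC)c1OC`: in a functional assay on MDA-MB-231 cells (Homo sapiens) for cytotoxicity, read by MTT assay, with a stated time of 48 h (on this read-out higher numbers stand for weaker inhibition and lower numbers for stronger inhibition), compound 1 gives 15.1 ug/mL
- compound 2, `COc1cc(-n2c(-c3ccc(C)cc3)csc2=S)cc(OC)c1OC`: in this assay compound 2 gives 11.8 ug/mL

Of these two values, compound 2 has the smaller number, yet its gap to compound 1 lies within the usual scatter of repeated measurements, so the two cannot be told apart on these data.

Compound 3, `COc1ccc(-c2csc(=S)n2-c2cc(OC)c(OC)c(OC)c2)cc1`, has not yet been tested. It differs from compound 2 in one place: methoxy in place of methyl on an aromatic carbon. Within the data shown here, no measured pair shows what this change does in this assay, so the direction of any step is not known from the data. The change is small in size, and a step within the scatter, in either direction or none at all, is the expectation. Compound 3 is therefore estimated at 12 ug/mL, with a range from 6 ug/mL to 25 ug/mL, which is expected to mean a step of a 1.0-fold higher number from compound 2 to compound 3 (0.01 log units; within the scatter).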

Compound 3, half-maximal inhibitory concentration: 53.8 ug/mL
Estimate against measurement, compound 3: 4.5-fold (0.65 log units) below; the measured number lies above the stated range.
By their numbers in this assay, from the lowest: compounds 2 and 1 (each within the scatter of the next); then compound 3.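

Among these compounds, the change from 4-methylphenyl to 4-methoxyphenyl is the first single change that can be read in this assay, and it gives a 4.6-fold higher number from compound 2 to compound 3 (0.66 log units; beyond the scatter) toward weaker inhibition. This shows that the position para to a large group is not indifferent to what it carries: methoxy in place of methyl is enough to move the number beyond the scatter, which the two earlier compounds, differing in more than one place, could not reveal. The data offer no measured ground that would explain this step.

As far as these compounds go, what a hydroxyl, an amine or a longer chain such as ethoxy would do at this place stays open. One step also cannot say whether the loss belongs to methoxy alone or would follow from other groups here as well.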